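Swapping Trifluoromethyl for Bromo on the Triazole Aryl

This account rests on a few compounds, and the source may have more. Where it says the series, first, only, none or still open, it means among the compounds named here.

Of the compounds shown here, three built on the shared core have been tested in a functional assay on MCF7 cells (Homo sapiens) for cytotoxicity, read by MTT assay, with a stated time of 4 days; on this read-out higher numbers stand for weaker inhibition and lower numbers for stronger inhibition. Compound 1 `C=C1C[C@]23C[C@@]1(O)CC[C@H]2c1ccc(OS(=O)(=O)c2ccc(C)cc2)c(C)c1[C@@H]3Cn1cc(-c2ccc(C)cc2)nn1` gives only a limit of the assay, > 20000 nM, so no number is known for it (the limit of > 20000 nM in this assay, at which 1 of the 3 values shown sits). Compound 2 `C=C1C(=O)[C@]23C[C@@]1(O)CC[C@H]2c1ccc(O)c(C)c1[C@@H]3Cn1cc(-c2ccc(F)cc2)nn1` gives 1700 nM. Compound 3 `C=C1C(=O)[C@]23C[C@@]1(O)CC[C@H]2c1ccc(O)c(C)c1[C@@H]3Cn1cc(-c2ccc(C(F)(F)F)cc2)nn1` gives 1840 nM, and the step of a 1.1-fold higher number from compound 2 to compound 3 (0.03 log units; within the scatter) shows that these two numbers lie within the scatter of each other, so compound 3 stands together with compound 2 among the numbers shown.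

Compound 4 `C=C1C(=O)[C@]23C[C@@]1(O)CC[C@H]2c1ccc(O)c(C)c1[C@@H]3Cn1cc(-c2ccc(Br)cc2)nn1` differs from compound 3 in one place: bromo in place of trifluoromethyl on an aromatic carbon. Going by the values given here, the only measured step that bears on this place is a 1.1-fold higher number from compound 2 to compound 3 (0.03 log units; within the scatter), in which one group on an aromatic carbon replaced another without any change beyond the scatter. With a single comparison to go on, compound 4 is expected to give a number close to that of compound 3, a step of a 1.1-fold lower number from compound 3 to compound 4 (0.03 log units; within the scatter) that is estimated to stay within the scatter. The estimate for compound 4 in this assay is 1700 nM, with a range from 700 nM to 4500 nM.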

Compound 4, half-maximal inhibitory concentration: 270 nM
Compound 4: middle estimate off by 6.3-fold (0.80 log units), on the high side, and the stated range ends above it.
By their numbers in this assay, from the lowest: compound 4; then compounds 2 and 3 (each within the scatter of the next). At a limit, above all of these: compound 1.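

Before this result, the one comparison at this aromatic carbon, para to a large group, showed no change beyond the scatter, so the group there could have seemed not to matter in this assay at all. Bromo now shows that it can: 4-bromophenyl in place of 4-(trifluoromethyl)phenyl gives a 6.8-fold lower number from compound 3 to compound 4 (0.83 log units; beyond the scatter) and, set against fluoro, gives a 6.3-fold lower number from compound 2 to compound 4 (0.80 log units; beyond the scatter) in a clear separation from both groups, while trifluoromethyl and fluoro stay within the scatter of each other. Nothing measured here bears on why bromo stands apart from these two groups.

Still open, as far as these compounds go, is whether chloro, iodo, an amine or a carboxylic acid on this carbon would match bromo or fall back with fluoro and trifluoromethyl. Compound 1 gives > 20000 nM as a limit, not a number, and differs in more than one place, so it adds nothing about this position.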